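The source may hold more compounds than are shown below. What is called first, only, known or untested is meant among the compounds shown, and "the series" means these compounds.

Of the compounds shown here, three that share one core have been tested in a functional assay on SW-620 cells (Homo sapiens) for inhibition, read by MTT assay, with a stated time of 72 h; on this read-out higher numbers stand for weaker inhibition and lower numbers for stronger inhibition. Compound 1, `COc1cc(NC(C)CCCNC(=O)NNC(=O)Nc2cccc(F)c2)c2ncccc2c1`, gives 9500 nM. Compound 2, `COc1cc(NC(C)CCCNC(=O)NNC(=O)Nc2ccc(Br)cc2)c2ncccc2c1`, gives 17000 nM. Compound 3, `COc1cc(NC(C)CCCNC(=O)NNC(=O)Nc2cccc(Cl)c2)c2ncccc2c1`, gives 25000 nM. Among the compounds with values here, compound 3 thus carries the highest number of the three, but only the step of a 2.6-fold higher number from compound 1 to compound 3 (0.42 log units; beyond the scatter) sets it clearly apart from another compound, whereas the step of a 1.5-fold higher number from compound 2 to compound 3 (0.17 log units; within the scatter) leaves it indistinguishable from compound 2. The third step, a 1.8-fold higher number from compound 1 to compound 2 (0.25 log units; within the scatter), also stays within the scatter.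

Compound 4, `COc1cc(NC(C)CCCNC(=O)Nc2cccc(Cl)c2)c2ncccc2c1`, has not yet been measured. It differs from compound 3 in one place: 3-chlorophenyl in place of ((3-chlorophenyl)carbamoyl)amino on an amide-type nitrogen. None of the three measured steps bears directly on this change, since each of them swaps one halogen-bearing phenyl for another while the ((3-chlorophenyl)carbamoyl)amino piece remains in every measured compound. Within the data shown here, those swaps moved the number by no more than a 2.6-fold higher number from compound 1 to compound 3 (0.42 log units; beyond the scatter), a modest amount, but the change to compound 4 removes a whole piece, and no measured pair shows what that does. Compound 4 is therefore expected to land near compound 3, estimated at 30000 nM with a range from 8000 nM to 100000 nM. The step of a 1.2-fold higher number from compound 3 to compound 4 (0.08 log units; within the scatter) is expected to stay within the scatter, with the direction uncertain.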

Compound 4, half-maximal inhibitory concentration: 26000 nM
Estimate against measurement, compound 4: 1.2-fold (0.06 log units) above, and the stated range covers the measured number.
By their numbers in this assay, from the lowest: compounds 1, 2, 3 and 4 (each within the scatter of the next, the first and the last beyond it).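

Removing the ((3-chlorophenyl)carbamoyl)amino piece and leaving 3-chlorophenyl on the amide-type nitrogen gives a 1.0-fold higher number from compound 3 to compound 4 (0.02 log units; within the scatter) in this assay, so with this halogen, the whole piece can go without a shift that stands out from the scatter. The shorter compound also relates to the others as compound 3 does: a 1.5-fold higher number from compound 2 to compound 4 (0.18 log units; within the scatter) stays within the scatter, while a 2.7-fold higher number from compound 1 to compound 4 (0.44 log units; beyond the scatter) is a modest step beyond it. Nothing measured here explains why the number holds steady when the piece is gone.

As far as these compounds go, the only direct test of this removal is the pair with 3-chlorophenyl, so it remains open whether the same removal would leave the number steady with 3-fluorophenyl or 4-bromophenyl. From the compounds shown here alone, it is also open what would happen at this nitrogen if a group of a different kind, such as a carboxylic acid, an amine or a longer carbon chain, stood in place of the 3-chlorophenyl.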